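Amino added to the chloro-bearing core of compound 2

The compounds below may be only part of what the source reports. "The series", "measured", "known", "first", "only" and "open" are said of these compounds alone.

The three compounds measured here share a diamino-substituted fused core. Compound 1 `Nc1nc(N)c2c(Sc3ccc(Cl)c(Cl)c3)cccc2n1` gives 6.8 in an assay for inhibition of Dihydrofolate reductase (Homo sapiens); a higher number here means a more potent compound, by a factor of ten per unit of this negative logarithm, a lower number a less potent compound. Compound 2 `Nc1nc(N)c2c(Cl)cccc2n1` gives 6.25, and compound 3 `Nc1nc(N)c2c(S(=O)(=O)c3ccc4ccccc4c3)cccc2n1` gives 4.82. Compound 2 therefore stands second of the three: compound 1 sits above it, beyond the usual scatter, and compound 3 sits far below it, also beyond the scatter.

The unmeasured compound 4 `Nc1nc(N)c2c(Cl)c(N)ccc2n1` departs from compound 2 by one change: amino in place of hydrogen on an aromatic carbon. The new group sits ortho to the chloro group, on the six-membered carbon ring of the fused system. Going by the values given here, no measured pair in this set shows what such an addition does, so there is no step to lean on.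

Given that, the step is expected to be small, in either direction or none beyond the scatter, with the estimate for compound 4 set at 6.3, ranging from 5.6 to 7, which amounts to an expected step of a number 0.05 log units higher from compound 2 to compound 4 (within the scatter).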

Compound 4, logarithm of the reciprocal of the active concentration, log(1/C): 6.18
Compound 4: middle estimate off by 0.12 log units, on the high side; low and high end bracket the measured number.
By their numbers in this assay, from the lowest: compound 3; then compounds 4 and 2 (each within the scatter of the next); then compound 1.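

In this assay, amino in place of hydrogen on an aromatic carbon, ortho to a chloro group, gives a number 0.07 log units lower from compound 2 to compound 4 (within the scatter), so compound 2 and compound 4 cannot be told apart. Going by these compounds alone, this is the first look at this carbon, which carries hydrogen in all the earlier compounds; their differences lie only in the group that compound 2 has as chloro. The added amino group is therefore tolerated here, at least on the chloro-bearing core, and no information is available to explain the result beyond the numbers themselves.

On these data alone, whether a methyl, a hydroxyl or an acetamide at this carbon would also stay within the scatter of compound 2 remains open. So does whether amino would give a similar step on the core of compound 1, which carries a larger group in place of chloro.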